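A few compounds are considered here, and "the series" means these few. Any claim that something is new, unique, unknown or untested is made for them only; others in the source may bear on it.

Going by the values given here, in a functional assay on NCI-H226 cells (Homo sapiens) for inhibition (on this read-out lower numbers stand for stronger inhibition of growth and higher numbers for weaker inhibition of growth), compound 2 `NC(=O)c1cc(I)ccc1NC(=O)COc1ccccc1` gives the lower of the two numbers so far (4940 nM) and compound 1 `NC(=O)c1cc(Cl)ccc1NC(=O)COc1ccccc1` gives the higher (100000 nM). Compound 3 `COc1ccc(NC(=O)COc2ccccc2)c(C(N)=O)c1` has methoxy in place of iodo on an aromatic carbon, para to a large group (methoxy in place of iodo on an aromatic carbon). Among the compounds with values here, one measured step bears on this place, namely a 20-fold lower number from compound 1 to compound 2 (1.31 log units; beyond the scatter) with iodo in place of chloro, and no methoxy compound has a number yet. Going by that large step, removing the iodo of compound 2 (4940 nM) is expected to give a clear move to a higher number, though probably a smaller one. The estimated step is a 5.1-fold higher number from compound 2 to compound 3 (0.70 log units; beyond the scatter) and it remains unmeasured. For compound 3 the expected value is 25000 nM with an estimated range of 7000 nM to 90000 nM in this series.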

Compound 3, concentration for 50% growth inhibition: 21500 nM
Estimate against measurement, compound 3: 1.2-fold (0.07 log units) above; the measured number falls inside the stated range.
By their numbers in this assay, from the lowest: compound 2; then compound 3; then compound 1.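

In this assay this position, para to a large group, now carries a third group, and the change to methoxy gives a 4.4-fold higher number from compound 2 to compound 3 (0.64 log units; beyond the scatter) and also a 4.7-fold lower number from compound 1 to compound 3 (0.67 log units; beyond the scatter) with chloro as the group replaced. Both steps lie beyond the scatter, so methoxy ranks clearly apart from iodo and from chloro, and a lower number here is not confined to iodo. No measurement offers an explanation for this order of the three groups. Still open, on these data alone, is how an amine, a carboxylic acid or a longer alkoxy chain at this place would rank against these three, and whether any such group would give a lower number than compound 2 does.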